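The source may hold more compounds than are shown below. What is called first, only, known or untested is meant among the compounds shown, and "the series" means these compounds.

Measured so far in a functional assay on MIA PaCa-2 cells (Homo sapiens) for inhibition, read by MTT assay, with a stated time of 7 days; a lower number here means a stronger inhibitor, a higher number a weaker inhibitor:
- compound 1, `O=C([C@@H]1CCCN(S(=O)(=O)c2ccc(S(=O)(=O)N3CC[C@@H](O)C3)cc2)C1)N1CCC(F)(F)CC1`: 210 nM
- compound 2, `CCN(CC)S(=O)(=O)c1ccc(S(=O)(=O)N2CCC[C@@H](C(=O)NC3COC3)C2)cc1`: 2340 nM
- compound 3, `CCN(CC)S(=O)(=O)c1ccc(S(=O)(=O)N2CCC[C@@H](C(=O)N[C@H]3CC[C@H](OC)CC3)C2)cc1`: 1350 nM

Compound 1 gives the lowest number of the three, and its gaps to compound 3 and to compound 2 both lie beyond the scatter, so it is the strongest inhibitor of the set. Compound 2 and compound 3 differ from each other only on the amide-type nitrogen, and that step, a 1.7-fold lower number from compound 2 to compound 3 (0.24 log units; within the scatter), stays within the scatter.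

Compound 4, `CC(C)S(=O)(=O)c1ccc(S(=O)(=O)N2CCC[C@@H](C(=O)N3CCC(F)(F)CC3)C2)cc1`, is derived from compound 1 by one change: isopropyl in place of 3-hydroxypyrrolidin-1-yl on a sulfonyl sulfur. Going by the values given here, no measured step touches the sulfonyl sulfur; compound 2 and compound 3 differ from compound 1 in more than one place, so their values do not isolate this change. Among the compounds with values here, the only step available, on the amide-type nitrogen, was small. Within the data shown here, with no direct precedent, the expected outcome is a step from compound 1 to compound 4 of a 1.7-fold higher number from compound 1 to compound 4 (0.22 log units; within the scatter) in this assay, of modest size and uncertain direction, with a slight lean toward a higher number since a hydrogen-bond donor leaves. Compound 4 is therefore estimated at 350 nM in this assay, within a range of 120 nM to 1000 nM.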

Compound 4, half-maximal inhibitory concentration: 11 nM
Estimate against measurement, compound 4: 32-fold (1.50 log units) above, outside the stated range (below it).
By their numbers in this assay, from the lowest: compound 4; then compound 1; then compounds 3 and 2 (each within the scatter of the next).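

In this assay, going by these compounds alone, the group on the sulfonyl sulfur proves to be a strong determinant of the read-out, since isopropyl in place of 3-hydroxypyrrolidin-1-yl gives a 19-fold lower number from compound 1 to compound 4 (1.28 log units; beyond the scatter) and is the first measured step at this place. Within the data shown here, its size sets this place apart from the amide-type nitrogen, where the only earlier step stayed within the scatter. The change removes a ring, a hydrogen-bond donor, a hydrogen-bond acceptor and a defined stereocentre together, and nothing shown gives a reason for the size of the step.

The compounds shown leave open which of these differences carries the step. Pyrrolidin-1-yl without the hydroxyl would separate the hydroxyl from the ring, while cyclopropyl or tert-butyl on the same sulfur would test how far the isopropyl result extends.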